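Halogen swap on the benzylsulfanyl ring: compound 3 to compound 4

A few compounds are considered here, and "the series" means these few. Any claim that something is new, unique, unknown or untested is made for them only; others in the source may bear on it.

Measured so far:
compound 1, `CC1=C(C(=O)Nc2ccc(Br)cc2)C(c2ccc(Cl)cc2Cl)N=C(SCc2ccccc2)N1`, 3.6%
compound 2, `CC1=C(C(=O)Nc2ccc(Br)cc2)C(c2ccc(Cl)cc2Cl)N=C(SCc2ccccc2Cl)N1`, 5.7%
compound 3, `CC1=C(C(=O)Nc2ccc(Br)cc2)C(c2ccc(Cl)cc2Cl)N=C(SCc2ccc(Cl)cc2)N1`, 6.7%

All three share one core and differ only on the ring of the benzylsulfanyl group. In a functional assay on the whole organism (artery, strain albino) with Rattus norvegicus as the target, with a stated time of 30 min, at a dose of 10 mg/kg by the oral route (on this read-out lower numbers stand for less inhibition and higher numbers for more inhibition at the one dose given (going by the name of the read-out)), compound 3 gives the largest of the three numbers, yet its distance to the others is small: a number 3.1 percentage points higher from compound 1 to compound 3 (within the scatter) and a number 1 percentage points higher from compound 2 to compound 3 (within the scatter), both within the scatter. The third measured step, a number 2.1 percentage points higher from compound 1 to compound 2 (within the scatter), is likewise within the scatter. For the measured compounds named here, nothing measured so far separates any two members beyond noise; the read-out sits low throughout.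

Compound 4, `CC1=C(C(=O)Nc2ccc(Br)cc2)C(c2ccc(Cl)cc2Cl)N=C(SCc2ccc(F)cc2)N1`, is not yet measured. It differs from compound 3 in one place: fluoro in place of chloro on an aromatic carbon. Going by the values given here, the steps that bear on this are those that alter the same ring, namely a number 3.1 percentage points higher from compound 1 to compound 3 (within the scatter) and a number 1 percentage points higher from compound 2 to compound 3 (within the scatter), and both were within the scatter. A change of one halogen for another at the same place is therefore not expected to move the number in this assay beyond the scatter in either direction; the expected step is a number 1.2 percentage points lower from compound 3 to compound 4 (within the scatter).

For compound 4 the expected value in this assay is 5.5%, with a range from 0% to 12%.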

Compound 4, a percentage reported as inhibition, in the whole organism at one dose (the size of the read-out at that dose, not a potency): 7.7%
Compound 4: middle estimate off by 2.2 percentage points, on the low side; measured number inside the range.
By their numbers in this assay, from the lowest: compounds 1, 2, 3 and 4 (each within the scatter of the next).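

In this assay, fluoro in place of chloro on this aromatic carbon, para to a large group, gives a number 1 percentage points higher from compound 3 to compound 4 (within the scatter), so the two halogens are not told apart at this place. The other two comparisons extend this to the wider set of rings: the step to 4-fluorobenzyl from the ring without a halogen reads a number 4.1 percentage points higher from compound 1 to compound 4 (within the scatter), and the step to it from the 2-chlorophenyl ring reads a number 2 percentage points higher from compound 2 to compound 4 (within the scatter), so fluoro joins chloro in leaving the number within the scatter of every other compound in the series. No measurement is at hand that could account for these small steps or for the low read-out across the series.

On these data alone, whether any change on this ring can move the number beyond the scatter stays open, for example an amine or a carboxylic acid on the same aromatic carbon, or a longer chain in place of the 4-fluorobenzyl group. Only this ring varies among the compounds shown, and what the shared core itself contributes to the read-out remains unknown.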